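The compounds below may be only part of what the source reports. "The series", "measured", "known", "first", "only" and "open" are said of these compounds alone.

Measured values:
- Compound 1 `Cc1ccc(S(=O)(=O)N2C=CNC(=O)[C@H]2CC(=O)N[C@H]2CCN(C3CCCC3)CC2(C)C)cc1`: < 14 mL.min-1.g-1
- Compound 2 `CC1(C)CNCC[C@@H]1NC(=O)C[C@@H]1C(=O)NC=CN1S(=O)(=O)c1ccc(Cl)c(Cl)c1`: < 50 mL.min-1.g-1
- Compound 3 `Cc1cc(S(=O)(=O)N2C=CNC(=O)[C@H]2CC(=O)N[C@H]2CCNCC2(C)C)c(C)cc1Cl`: 21 mL.min-1.g-1

Within the data shown here, in an in vitro ADME assay on microsomes from liver (Homo sapiens) for pharmacokinetics (a lower number here means slower removal, a higher number faster removal of the compound), compound 3 gives the only exact number, 21 mL.min-1.g-1. Compound 1 sits at the limit of < 14 mL.min-1.g-1 in this assay, at which 1 of the 3 values shown sits. Compound 2 sits at the limit of < 50 mL.min-1.g-1 in this assay, at which 1 of the 3 values shown sits. Neither of these two limits is a number.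

Compound 4 `Cc1cc(S(=O)(=O)N2C=CNC(=O)[C@H]2CC(=O)N2CCC3(CCN(C)C3)C2)c(C)cc1Cl` differs from compound 3 on a carbonyl carbon: a group of 10 heavy atoms (8 carbon, 2 nitrogen; 2 five-membered non-aromatic rings with 1 hetero atom each) in place of a group of 9 heavy atoms (7 carbon, 2 nitrogen; one six-membered non-aromatic ring with 1 hetero atom), on a carbonyl carbon.

Among the measured compounds shown here, the only measured step, a step that the limit leaves unreadable from compound 2 to compound 3, swaps a group on a sulfonyl sulfur, not the group on the carbonyl carbon. For the measured compounds named here, no measured step therefore gives a size for this change. With compound 3 at 21 mL.min-1.g-1 as the only firm anchor, the expectation stays close to that number, and no direction is firmly supported.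

The expected change is a 1.3-fold higher number from compound 3 to compound 4 (0.11 log units; within the scatter), and no step beyond the usual scatter is expected.

For compound 4 the estimated value in this assay is 27 mL.min-1.g-1, with an expected range of 11 mL.min-1.g-1 to 65 mL.min-1.g-1.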

Compound 4, intrinsic clearance in microsomes: 28 mL.min-1.g-1
For compound 4 the middle estimate is 1.0-fold (0.02 log units) below the measured one; the range from low to high includes it.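

In this assay, setting the group with 2 five-membered non-aromatic rings in place of the group with one six-membered non-aromatic ring, on a carbonyl carbon, gives a 1.3-fold higher number from compound 3 to compound 4 (0.12 log units; within the scatter). Among these compounds, this is the first step here that can be read as a size, and it shows that this whole group can be exchanged, with hydrogen-bond donors going from 2 to 0 and the defined stereocentre gone, without a step beyond the usual scatter. Nothing measured here gives a reason for this result.

A single exchange cannot separate the ring change, the lost donors and the lost stereocentre from one another. Going by these compounds, how an open-chain amine such as a dimethylaminoethyl group, or a carboxylic acid, would behave on this carbonyl carbon stays open.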